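Second aryl methyl and kinetic solubility: working notes

This account rests on a few compounds, and the source may have more. Where it says the series, first, only, none or still open, it means among the compounds named here.

Measured so far:
- compound 1 `Cc1ccccc1-c1nc(CN2CCC(C(=O)NCCCCN3C[C@H](C)C[C@H](C)C3)CC2)c(C)o1`: in a physicochemical assay for solubility, in phosphate buffer, measured as kinetic solubility, at pH 7.4 (on this read-out lower numbers stand for lower solubility and higher numbers for higher solubility), compound 1 gives > 71 ug/mL, a limit of the assay rather than a number.
- compound 2 `Cc1cccc(-c2nc(CN3CCC(C(=O)NCCCN4C[C@H](C)C[C@H](C)C4)CC3)c(C)o2)c1`: in this assay compound 2 gives > 69 ug/mL, again a limit rather than a number.

Among the compounds with values here, both values shown are limits, as recorded in the limit of > 69 ug/mL in this assay, at which 1 of the 2 values shown sits, and (the limit of > 71 ug/mL in this assay, at which 1 of the 2 values shown sits), so no step between measured compounds can be computed, and compound 2 stands only as a compound whose solubility lies at or beyond its limit. Nothing in the measured pair separates the two aryl substitution patterns.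

Compound 3 `Cc1cc(C)cc(-c2nc(CN3CCC(C(=O)NCCCN4C[C@H](C)C[C@H](C)C4)CC3)c(C)o2)c1`, not yet measured, differs from compound 2 by methyl in place of hydrogen on an aromatic carbon. Within the data shown here, no measured step covers such a change, so the expectation rests on the change alone. A small downward step an at least 1.2-fold lower number from compound 2 to compound 3 (0.09 log units; that floor lies within the scatter) is expected for compound 3, with a fair chance that the assay again returns only a limit.

For compound 3 the estimate in this assay is 55 ug/mL, with a range from 20 ug/mL to 100 ug/mL.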

Compound 3, solubility: > 71 ug/mL
Compound 3 gave a limit, no number; the forecaster's own chance of this, stated with the estimate: 45%; middle value at least 1.2-fold (0.11 log units) from the limit.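

In this assay compound 3 gives > 71 ug/mL, a limit of the assay and not a number. Compound 2 also stands only at a limit, so no step can be read between compound 2 and compound 3. The compounds shown leave open whether the change from 3-methylphenyl to 3,5-dimethylphenyl moves this read-out at all.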